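From oxolan-3-yl to 1H-pyrrol-3-yl on a carbonyl carbon

The compounds below may be only part of what the source reports. "The series", "measured", "known", "first", "only" and "open" are said of these compounds alone.

Of the compounds shown here, three have numbers so far in a physicochemical assay for solubility, read by mass spectrometry, in phosphate buffer, with a stated time of 24 h, at pH 7.4; on this read-out lower numbers stand for lower solubility and higher numbers for higher solubility. Compound 2 (`O=C(Nc1ccc(OC(F)(F)F)cc1)NC1CCN(C(=O)[C@@H]2CCOC2)CC1`) reads 23 ug/mL and stands in the middle of the three. Compound 1 (`O=C(Nc1ccc(OC(F)(F)F)c(F)c1)NC1CCN(C(=O)C2(C(F)(F)F)CC2)CC1`) is higher at 92 ug/mL, and compound 3 (`CCC(=O)N1CCC(NC(=O)Nc2ccc(C(F)(F)F)c(F)c2)CC1`) is lower at 3.9 ug/mL. Both gaps to compound 2 lie beyond the scatter.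

Compound 4 (`O=C(Nc1ccc(OC(F)(F)F)cc1)NC1CCN(C(=O)c2cc[nH]c2)CC1`) has not yet been measured. The structural change from compound 2 to compound 4 is 1H-pyrrol-3-yl in place of oxolan-3-yl on a carbonyl carbon. In words, 1H-pyrrol-3-yl takes the place of oxolan-3-yl on a carbonyl carbon, and the amide-type nitrogen in a ring stays as it is.

Going by the values given here, no two measured compounds differ in only one place, so no measured step shows what this swap does. The expectation is therefore a judgement, held loosely. The expected step in this assay is a downward one, a 2.3-fold lower number from compound 2 to compound 4 (0.36 log units; beyond the scatter). For compound 4 the estimated value is 10 ug/mL, with an expected range of 3 ug/mL to 30 ug/mL.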

Compound 4, solubility: 43 ug/mL
Compound 4: middle estimate off by 4.3-fold (0.63 log units), on the low side; measured number outside the range, above it.
By their numbers in this assay, from the lowest: compound 3; then compounds 2 and 4 (each within the scatter of the next); then compound 1.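

In this assay, going by these compounds alone, the change at this position gives a 1.9-fold higher number from compound 2 to compound 4 (0.27 log units; within the scatter), the only step so far that can be read at a single place. Here, on a carbonyl carbon bonded to the amide-type nitrogen in a ring, the read-out does not separate the five-membered non-aromatic ring of oxolan-3-yl from the five-membered aromatic ring of 1H-pyrrol-3-yl, even though the hydrogen-bond acceptor gives way to a hydrogen-bond donor and the defined stereocentre is lost. No measured evidence bears on the origin of this result.

Open, from the compounds shown here alone, is whether a carboxylic acid, an amine or a longer chain at this place would give a step beyond the scatter. Also open, going by these compounds, is whether the same swap reads alike on the cores of compound 1 and compound 3.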